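The compounds below may be only part of what the source reports. "The series", "measured", "known", "first", "only" and "open" are said of these compounds alone.

Measured so far:
compound 1, `Cn1nnnc1SCC(=O)Nc1ccc(-c2nc(-c3ccccc3)c(-c3ccccc3)n2C)cc1`: 1.6 ug/mL
compound 2, `Cn1c(-c2ccc(NC(=O)CSC3=NCCS3)cc2)nc(-c2ccccc2)c1-c1ccccc1`: 21 ug/mL
compound 3, `CCN1CCN(CC(=O)Nc2ccc(-c3nc(-c4ccccc4)c(-c4ccccc4)n3C)cc2)CC1`: 75 ug/mL

All three share the same core and differ only in the tail attached to the amide carbonyl. In a functional assay on HT-29 cells (Homo sapiens) for cytotoxicity, read by MTT assay, with a stated time of 24 h (a lower number here means a stronger inhibitor, a higher number a weaker inhibitor), compound 1 gives 1.6 ug/mL, compound 2 gives 21 ug/mL, and compound 3 gives 75 ug/mL. Compound 3 therefore stands at the top of the three numbers and is the weakest inhibitor of the set: the step of a 3.6-fold higher number from compound 2 to compound 3 (0.55 log units; beyond the scatter) and the step of a 47-fold higher number from compound 1 to compound 3 (1.67 log units; beyond the scatter) both lie beyond the scatter.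

Compound 4, `Cc1ccc(CN2CCN(CC(=O)Nc3ccc(-c4nc(-c5ccccc5)c(-c5ccccc5)n4C)cc3)CC2)cc1`, keeps the tail of compound 3 and alters only its far end: 4-methylphenyl in place of methyl on a saturated chain carbon bound to an amine nitrogen in a ring. Going by the values given here, none of the measured steps touches this place. The steps of a 47-fold higher number from compound 1 to compound 3 (1.67 log units; beyond the scatter) and a 3.6-fold higher number from compound 2 to compound 3 (0.55 log units; beyond the scatter) exchanged the whole tail and show that the tail matters a great deal, but they say nothing about enlarging the group on the ring nitrogen of compound 3. Among the compounds with values here, with no direct precedent, the expected step is modest at most, its direction uncertain: a 1.9-fold lower number from compound 3 to compound 4 (0.27 log units; within the scatter). The estimate for compound 4 in this assay is 40 ug/mL, within a range from 10 ug/mL to 150 ug/mL.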

Compound 4, half-maximal inhibitory concentration: 62 ug/mL
Beside the measured number, compound 4's estimate is 1.6-fold (0.19 log units) below it; the measured number falls inside the stated range.
By their numbers in this assay, from the lowest: compound 1; then compound 2; then compounds 4 and 3 (each within the scatter of the next).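

In this assay, putting 4-methylphenyl in place of methyl on a saturated chain carbon bound to an amine nitrogen in a ring gives a 1.2-fold lower number from compound 3 to compound 4 (0.08 log units; within the scatter), so a much larger group at the far end of this tail leaves the number within the scatter. The earlier steps shown here exchanged the whole tail and moved the number well beyond the scatter, as in a 47-fold higher number from compound 1 to compound 3 (1.67 log units; beyond the scatter), whereas this pair shows that, for these two groups, the far end of the ring tail makes no readable difference, and in this assay compound 4 gives 62 ug/mL and compound 1 gives 1.6 ug/mL. No measurement is available that would explain this flat result.

A single pair cannot show whether this place is insensitive to every change, and a carboxylic acid or an amine on the benzyl ring, or a longer chain in its place, could still shift the number. From the compounds shown here alone, it also remains open whether any change at this far end could bring a ring tail of this kind close to the tail of compound 1.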